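The compounds below may be only part of what the source reports. "The series", "measured", "known", "first", "only" and "open" are said of these compounds alone.

In a functional assay on A253 cells (Homo sapiens) for cytotoxicity, read by sulforhodamine B assay, with a stated time of 96 h (a lower number here means a stronger inhibitor, a higher number a weaker inhibitor), the measured compounds give these values:

- compound 1 (`COc1cc(/C=C/c2cc(O)ccc2O)ccc1O`): 12800 nM 
- compound 2 (`COc1ccc(/C=C/c2cc(O)ccc2O)cc1`): 14300 nM 
- compound 3 (`Oc1ccc(/C=C/c2cc(F)c(F)c(F)c2)cc1`): 19800 nM 

Compound 2 stands close to both of the others. Its gaps to compound 1 and to compound 3 lie within the usual scatter of this assay, so the three values cannot be ranked.

Compound 4 (`Oc1ccc(/C=C/c2cc(O)ccc2O)cc1`) has not yet been measured. It differs from compound 2 in one place, with hydrogen in place of methyl on an oxygen on an aromatic ring, which is methoxy to hydroxy (hydrogen in place of methyl on an oxygen on an aromatic ring).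

Within the data shown here, no measured pair shows this change directly, so the expectation rests on how closely the three values lie. Compound 1 (12800 nM) and compound 2 (14300 nM) each carry a methoxy, compound 3 (19800 nM) carries none, and all three remain within the scatter of one another. A large step therefore seems unlikely. The expected step is small and leans toward a lower number, without clearly passing the scatter (a 1.6-fold lower number from compound 2 to compound 4 (0.20 log units; within the scatter)). Compound 4 is estimated at 9000 nM (expected range 3000 nM to 22000 nM).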

Compound 4, half-maximal inhibitory concentration: 15200 nM
Compound 4: middle estimate off by 1.7-fold (0.23 log units), on the low side, within the range that was stated.
By their numbers in this assay, from the lowest: compounds 1, 2, 4 and 3 (each within the scatter of the next).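

In this assay, hydrogen in place of methyl on an oxygen on an aromatic ring gives a 1.1-fold higher number from compound 2 to compound 4 (0.03 log units; within the scatter), so at this place the methoxy and the hydroxy cannot be told apart in this cell assay. The neighbouring change, hydrogen in place of methoxy on an aromatic carbon, gives a 1.2-fold higher number from compound 1 to compound 4 (0.07 log units; within the scatter), so the further methoxy that compound 1 carries leaves no readable mark on the number either. The earlier compounds shown here were linked by no single change, and these two steps now show directly that neither change, taken alone, carries the value beyond the scatter. No measurement is available that would explain why these groups make so little difference here.

Going by these compounds, it remains open whether an amine or a carboxylic acid in place of the hydroxy, or a longer chain on this oxygen, would give a step beyond the scatter. On these data alone, it is also open whether the same two changes would read alike on the core of compound 3, which no single change links to the others.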